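This account rests on a few compounds, and the source may have more. Where it says the series, first, only, none or still open, it means among the compounds named here.

Measured compounds:
Compound 1, `Cc1ccc2c(c1)O[C@H](c1ccccc1)CC2=O`: 110 nM
Compound 2, `O=C1CC(c2ccccc2)Oc2ccccc21`: 2870 nM
Compound 3, `COc1ccc2c(c1)OC(c1ccccc1)CC2=O`: 1470 nM

In an in vitro assay on BTI-TN-5B1-4 cells for inhibition of Amine oxidase [flavin-containing] B (Homo sapiens) (a lower number here means a stronger inhibitor, a higher number a weaker inhibitor), compound 3 gives the second highest of the three numbers. Its nearest neighbour is compound 2, and the step of a 2.0-fold lower number from compound 2 to compound 3 (0.29 log units; within the scatter) is within the scatter, so these two cannot be told apart. Going by the values given here, compound 1 gives a number well below that of compound 3, but the two structures differ in more than one place, so no single step links them.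

Compound 4, `COc1ccc2c(c1)OC(c1ccc(C)cc1)CC2=O`, is not yet measured. It comes from compound 3 by methyl in place of hydrogen on an aromatic carbon, the change sitting on an aromatic carbon of a six-membered aromatic ring of carbon only. None of the measured steps concerns this change: the only step shown, a 2.0-fold lower number from compound 2 to compound 3 (0.29 log units; within the scatter), puts a methoxy in place of hydrogen on a different aromatic carbon, and compound 1 carries its methyl on another ring. There is therefore no basis for expecting a step beyond the scatter in this assay in either direction, and the expected step of a 1.2-fold lower number from compound 3 to compound 4 (0.09 log units; within the scatter) is set as a small one. Compound 4 is expected to give about 1200 nM in this assay, with a range from 400 nM to 3600 nM.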

Compound 4, half-maximal inhibitory concentration: 550 nM
Compound 4: the middle estimate sits 2.2-fold (0.34 log units) above what was measured; the measured number falls inside the stated range.
By their numbers in this assay, from the lowest: compound 1; then compound 4; then compounds 3 and 2 (each within the scatter of the next).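

In this assay, a single methyl in place of hydrogen, on an aromatic carbon para to a large group, gives a step beyond the scatter: a 2.7-fold lower number from compound 3 to compound 4 (0.43 log units; beyond the scatter). Going by these compounds alone, the only earlier single change, a 2.0-fold lower number from compound 2 to compound 3 (0.29 log units; within the scatter), put a methoxy on a different aromatic carbon and stayed within the scatter, so this is the first one-place change here that can be read as a real, though modest, gain in inhibition. No measurement shown accounts for why adding this one carbon lowers the number.

As far as these compounds go, it remains open whether the gain belongs to methyl in particular or would also appear with another group on the same carbon, such as a chlorine atom, an amine, a carboxylic acid or a longer chain. From the compounds shown here alone, it is also open whether the same methyl would give a step of similar size on compound 2, which has no methoxy, or on compound 1, which carries a methyl on its other aromatic ring.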